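Dropping the Benzyl Group: Expectation for Compound 4

This account rests on a few compounds, and the source may have more. Where it says the series, first, only, none or still open, it means among the compounds named here.

Compound 3 `CCCCCCCC/N=c1\nc(N)c2ncn(Cc3ccccc3)c2c(N)n1` was tested in a functional assay on OVCAR-3 cells (Homo sapiens) for antiproliferative activity, read by WST assay, with a stated time of 72 h (a higher number here means a weaker inhibitor, a lower number a stronger inhibitor), where compound 3 gives 4980 nM. Among the three compounds measured so far, compound 3 stands second highest. Its nearest neighbour is compound 2 `CCCCCCCCCC/N=c1\nc(N)c2ncn(Cc3ccccc3)c2c(N)n1`, which in this assay gives 3950 nM, a gap that lies within the scatter of the method. Furthest away is compound 1 `Nc1n/c(=N\CCCCc2ccccc2)nc(N)c2c1ncn2Cc1ccccc1`, which in this assay gives 37300 nM. The measured steps all concern the chain hanging from the double-bonded nitrogen: a 9.4-fold lower number from compound 1 to compound 2 (0.98 log units; beyond the scatter), a 7.5-fold lower number from compound 1 to compound 3 (0.87 log units; beyond the scatter) and a 1.3-fold higher number from compound 2 to compound 3 (0.10 log units; within the scatter). Swapping phenyl for a plain alkyl group at the end of that chain made a modest difference, while shortening the alkyl did not.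

Compound 4 `CCCCCCCC/N=c1\nc(N)c2nc[nH]c2c(N)n1` differs from compound 3 at another site: hydrogen in place of benzyl on an aromatic nitrogen. Within the data shown here, no measured step touches this ring nitrogen, so there is no direct precedent for the change, and the chain steps say nothing about it. The expectation is therefore a step of a 1.8-fold higher number from compound 3 to compound 4 (0.26 log units; within the scatter) in this assay, with a deliberately wide range. Compound 4 is estimated at 9000 nM, expected to fall between 2500 nM and 35000 nM.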

Compound 4, half-maximal inhibitory concentration: "not active" (no number reported)
Compound 4 has no reported number here, so the estimate cannot be set against anything.
By their numbers in this assay, from the lowest: compounds 2 and 3 (each within the scatter of the next); then compound 1.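

Among these compounds, compound 4 is reported in this assay only as "not active", without a number, so no step from compound 3 to compound 4 can be read. No supporting data bear on this result. The compounds shown leave open how hydrogen in place of benzyl on the aromatic nitrogen acts when the chain on the shared core differs.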